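The source may report more compounds than this note shows. Statements on the series, on what has been measured and on what is new or still open speak of the compounds shown alone.

In a physicochemical assay for lipophilicity (on this read-out higher numbers stand for higher lipophilicity and lower numbers for lower lipophilicity), compound 1 `C/C(=C\S(=O)(=O)NC1CCN(c2ccc(-n3ccnc3CN(C)C)cc2F)C1=O)c1ccc(Cl)s1` gives 2.44. Two relatives differ from it only in the group on the sulfonyl sulfur: compound 2 `CN(C)Cc1nccn1-c1ccc(N2CCC(NS(=O)(=O)CCc3ccc(Cl)s3)C2=O)c(F)c1` gives 2.32, and compound 3 `CN(C)Cc1nccn1-c1ccc(N2CCC(NS(=O)(=O)c3cc4ccc(Cl)cc4s3)C2=O)c(F)c1` gives 2.58. Compound 1 therefore stands among three values that cannot be told apart, with a number 0.12 log units lower from compound 1 to compound 2 (within the scatter) and a number 0.14 log units higher from compound 1 to compound 3 (within the scatter). The remaining step, a number 0.26 log units higher from compound 2 to compound 3 (within the scatter), also falls inside the usual scatter.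

Compound 4 `C/C(=C\S(=O)(=O)NC1CCN(c2ccc(-n3cncc3CN(C)C)cc2F)C1=O)c1ccc(Cl)s1` keeps the sulfonyl group of compound 1 and changes something else: 5-((dimethylamino)methyl)-1H-imidazol-1-yl in place of 2-((dimethylamino)methyl)-1H-imidazol-1-yl on an aromatic carbon. The two compounds have the same atoms, joined differently. None of the three measured steps touches this group, since each one exchanges the group on the sulfonyl sulfur. For the measured compounds named here, they bear on the new change only indirectly, and no measured pair shows what this kind of move does. With no direct guide, the sensible starting point is the value of the closest measured relative, and the range has to stay wide. The expected step is a number 0.04 log units lower from compound 1 to compound 4 (within the scatter), which means no change beyond the scatter is anticipated in this assay. For compound 4 the estimated value is 2.4, with an expected range from 1.9 to 2.9.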

Compound 4, distribution coefficient: 2.31
The estimate for compound 4 lay 0.09 log units above the measured number; low and high end bracket the measured number.
By their numbers in this assay, from the lowest: compounds 4, 2, 1 and 3 (each within the scatter of the next).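

Moving the side chain around the ring, so that 5-((dimethylamino)methyl)-1H-imidazol-1-yl stands in place of 2-((dimethylamino)methyl)-1H-imidazol-1-yl on the aromatic carbon para to a large group, gives a number 0.13 log units lower from compound 1 to compound 4 (within the scatter) in this assay and so no difference that can be told from repeat noise. For the compounds shown here, this is the first look at this part of the molecule, and it shows that a rearrangement keeping the same atoms, the same count of hydrogen-bond acceptors and the same single five-membered aromatic ring leaves this read-out where the exchanges on the sulfonyl sulfur left it, inside the scatter. Nothing measured here explains this outcome or says whether it would hold in any other setting.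

The compounds shown leave open whether the same rearrangement would read alike with 2-(5-chlorothiophen-2-yl)ethyl or 6-chloro-1-benzothiophen-2-yl on the sulfonyl sulfur in place of the group carried by compound 1. They also leave open what this read-out would give if the dimethylamino part of the side chain gave way to a morpholine, or to a carboxylic acid.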